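The compounds below may be only part of what the source reports. "The series", "measured", "known", "first", "only" and "open" are said of these compounds alone.

In a functional assay on TK-10 cells (Homo sapiens) for inhibition, read by sulforhodamine B assay, with a stated time of 48 h (on this read-out higher numbers stand for weaker inhibition of growth and lower numbers for stronger inhibition of growth), compound 1 `COc1ccc(CNc2nc3cc(N)cc(N)c3nc2-c2ccccc2)cc1OC` gives 32400 nM, the higher of the two numbers measured, while compound 2 `COc1cc(CNc2nc3cc(N)cc(N)c3nc2-c2ccccc2)cc(OC)c1OC` gives 17800 nM; that step, a 1.8-fold lower number from compound 1 to compound 2 (0.26 log units; within the scatter), adds a methoxy group. Compound 3 `COc1ccc(CNc2nc3cc(N)cc(N)c3nc2-c2ccccc2)cc1` differs from compound 1 by hydrogen in place of methoxy on an aromatic carbon. Among the measured compounds shown here, the only measured step that bears on this change is the one from compound 1 to compound 2, and it stayed within the scatter, so no step beyond the scatter is expected in this assay in either direction. Compound 3 is therefore estimated to give about 40000 nM, between 15000 nM and 100000 nM, which means an expected step of a 1.2-fold higher number from compound 1 to compound 3 (0.09 log units; within the scatter).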

Compound 3, concentration for total growth inhibition: 57500 nM
For compound 3 the middle estimate is 1.4-fold (0.16 log units) below the measured one, and the stated range covers the measured number.
By their numbers in this assay, from the lowest: compounds 2, 1 and 3 (each within the scatter of the next, the first and the last beyond it).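

In this assay, replacing the methoxy with hydrogen on this aromatic carbon, ortho to a methoxy group and meta to a large group, gives a 1.8-fold higher number from compound 1 to compound 3 (0.25 log units; within the scatter). The change from 3,4-dimethoxyphenyl to 4-methoxyphenyl therefore does not separate hydrogen from methoxy at this position, and it shows that this methoxy can be lost without a step beyond the scatter. From the compounds shown here alone, whether an amine, a carboxylic acid or a longer chain such as butoxy at this position would give a step beyond the scatter stays open. No measured evidence shown here bears on this result.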